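The source may report more compounds than this note shows. Statements on the series, on what has been measured and on what is new or still open speak of the compounds shown alone.

Of the compounds shown here, three sharing one fused two-ring core have been measured, and a fourth awaits its number. Compound 3 `ClCc1ccc(Cn2cnc3c(Cl)nc(Cl)nc32)cc1` and compound 2 `ClCc1cccc(Cn2cnc3c(Cl)nc(Cl)nc32)c1` are built from the same atoms joined differently; the difference between the two cores is not broken down here. Compound 1 `Nc1nc(Cl)c2ncn(Cc3ccc(CCl)cc3)c2n1` arises from compound 3 by the change (amino in place of chloro on an aromatic carbon), and compound 4 `Nc1nc(Cl)c2ncn(Cc3cccc(CCl)c3)c2n1` arises from compound 2 by the change (amino in place of chloro on an aromatic carbon), which is the same change at the same kind of place.

In a functional assay on LOX IMVI cells (Homo sapiens) for cytotoxicity, read by sulforhodamine B assay, with a stated time of 48 h (a lower number here means a stronger inhibitor of growth, a higher number a weaker inhibitor of growth), compound 3 gives 4170 nM, and compound 2 gives 3380 nM; these two values lie within the usual scatter of each other. Compound 1 gives 43700 nM in this assay, and the step of a 10-fold higher number from compound 3 to compound 1 (1.02 log units; beyond the scatter) is large and clearly beyond the scatter.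

Since the change from compound 2 to compound 4 matches the change from compound 3 to compound 1, and since compound 2 and compound 3 start from values within the scatter of each other, the expected step is a 10-fold higher number from compound 2 to compound 4 (1.02 log units; beyond the scatter), which rests on the measured step of a 10-fold higher number from compound 3 to compound 1 (1.02 log units; beyond the scatter). On that basis compound 4 is estimated at 35000 nM in this assay, with an expected range from 12000 nM to 100000 nM. Only one prior example of this change exists among these compounds, so the expectation carries the width of that range.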

Compound 4, concentration for total growth inhibition: 13200 nM
For compound 4 the middle estimate is 2.7-fold (0.42 log units) above the measured one, within the range that was stated.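

In this assay, amino in place of chloro on an aromatic carbon again gives a weaker inhibitor of growth, with a 3.9-fold higher number from compound 2 to compound 4 (0.59 log units; beyond the scatter), so in both pairs the change moves the number the same way and by more than the usual scatter. The direction of the step therefore carried over from one core to the other, but its size did not, and the size of a step measured on one core was not a safe guide to its size on the other: the same change on two cores in this assay, a 10-fold higher number (1.02 log units; beyond the scatter) from compound 3 to compound 1 and a 3.9-fold higher number (0.59 log units; beyond the scatter) from compound 2 to compound 4, 2.7-fold (0.43 log units) apart, beyond the scatter of two such steps. These two pairs do not show why the size differs, since the cores are built from the same atoms joined differently and nothing here separates the possible reasons, nor do they show that the direction would hold on any core beyond these two.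

The compounds shown leave open whether a different group in the same place, such as a methylamino, a hydroxyl or a methoxy group, would also give a weaker inhibitor of growth on both cores. They also leave open whether the two cores would still differ in step size if the chloromethyl group gave way to a plain methyl or a hydroxymethyl group.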